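A few compounds are considered here, and "the series" means these few. Any claim that something is new, unique, unknown or untested is made for them only; others in the source may bear on it.

Measured in a functional assay on U-251 cells (Homo sapiens) for inhibition, read by MTT assay, with a stated time of 2 days; on this read-out higher numbers stand for weaker inhibition of growth and lower numbers for stronger inhibition of growth:
- compound 1 `Nc1ccccc1NC(=O)CCCNCC(=O)Nc1cccc(Cl)c1`: > 100000 nM (a limit of the assay, not a number)
- compound 2 `Nc1ccccc1NC(=O)CCCNCC(=O)Nc1ccc(Cl)cc1`: 75000 nM
- compound 3 `Nc1ccccc1NC(=O)CCCNCC(=O)Nc1cccc([N+](=O)[O-])c1`: 93500 nM

Compound 1 sits at the limit of the limit of > 100000 nM in this assay, at which 1 of the 3 values shown sits. Within the data shown here, only two true numbers exist in this assay: compound 2 gives 75000 nM and compound 3 gives 93500 nM. Among the measured compounds shown here, the gap between them is a 1.2-fold higher number from compound 2 to compound 3 (0.10 log units; within the scatter), so compound 3 cannot be separated from its one measured neighbour.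

Next in the series is compound 4 `Nc1ccccc1NC(=O)CCCNCC(=O)Nc1cc(Cl)ccc1Cl`, with the change 2,5-dichlorophenyl in place of 3-nitrophenyl on an amide-type nitrogen. All three measured steps change this same aryl group. They are an at least 1.3-fold lower number from compound 1 to compound 2 (0.12 log units; that floor lies within the scatter), an at least 1.0-fold lower number from compound 1 to compound 3 (0.02 log units; that floor lies within the scatter) and the gap already given. None of them shows a change beyond the scatter, although the first two are only floors set by a limit. The 2,5-dichlorophenyl group has not been measured in any other compound, so the estimate rests on these small steps alone.

No step beyond the scatter is therefore expected, and the estimated step is a 1.2-fold lower number from compound 3 to compound 4 (0.10 log units; within the scatter). Compound 4 is expected at 75000 nM, with an estimated range of 35000 nM to 130000 nM.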

Compound 4, concentration for total growth inhibition: > 100000 nM
Compound 4: a limit, no number; the forecaster's own chance of this, stated with the estimate: 30%; at least 1.3-fold (0.12 log units) between middle value and limit.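

Compound 4 gives a limit and not a number in this assay, which makes 2,5-dichlorophenyl the second group on this amide-type nitrogen to end there: the limit of > 100000 nM in this assay, at which 2 of the 4 values shown sit.

Against the two measured neighbours, the change to 2,5-dichlorophenyl gives an at least 1.0-fold higher number from compound 3 to compound 4 (0.02 log units; that floor lies within the scatter) and an at least 1.3-fold higher number from compound 2 to compound 4 (0.12 log units; that floor lies within the scatter), so a group with two chlorines on the ring brings no lower number here than the single 4-chlorophenyl or 3-nitrophenyl groups, although both floors leave the true size of these steps unknown. The step between the two compounds that both sit at the limit cannot be read.

Going by these compounds, every readable step on this aryl group lies within the scatter, so it remains open whether any change at this place can move growth inhibition measurably, or whether the series stays at this weak end whatever the aryl group. Also open, on these data alone, is what an unsubstituted phenyl, a 4-methoxyphenyl or a pyridine ring would give on this nitrogen, and what a longer chain in the shared core would do to the number.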